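The source may report more compounds than this note shows. Statements on the series, on what has been measured and on what is new or still open speak of the compounds shown alone.

Working notes on the ester series.

Three compounds have numbers in a functional assay on PC-3 cells (Homo sapiens) for antiproliferative activity, read by sulforhodamine B assay, with a stated time of 48 h, tested at 50 uM (a higher number here means more inhibition at the concentration tested (going by the name of the read-out), a lower number less inhibition), so far. Compound 1 `Cc1cc2c(C(C)C)ccc(C)c2cc1OC(=O)c1ccc(C(F)(F)F)cc1` gives 100% in this assay. Compound 2 `CC1=CC[C@H](C(C)C)c2cc(C)c(OC(=O)c3ccc([N+](=O)[O-])cc3)cc21` gives 36.7% in this assay. Compound 3 `COc1cccc(C(=O)Oc2cc3c(C)ccc(C(C)C)c3cc2C)c1` gives 12.5% in this assay. On these three numbers compound 2 stands second highest: its nearest neighbour is compound 3, which lies lower by a gap beyond the scatter, and the furthest is compound 1, which lies higher by a gap beyond the scatter. Going by the values given here, compounds 1 and 3 differ from compound 2 in more than one place, so no single step between measured compounds can be read off.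

Compound 4 `CC1=CC[C@H](C(C)C)c2cc(C)c(OC(=O)c3ccccc3)cc21` is not yet measured. It differs from compound 2 in one place: hydrogen in place of nitro on an aromatic carbon. Read one bond further out, 4-nitrophenyl becomes phenyl on the ester. Among the compounds with values here, nothing among the measured compounds isolates the effect of the nitro group. The expected step is therefore none beyond the scatter, with a lean toward a slightly lower number. The step from compound 2 to compound 4 is estimated at a number 8.7 percentage points lower from compound 2 to compound 4 (within the scatter). Compound 4 is expected to give 28% in this assay, in the range 5% to 55%.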

Compound 4, a percentage reported as inhibition, at one concentration (the size of the read-out at that concentration, not a potency): 22.5%
Compound 4: the middle estimate sits 5.5 percentage points above what was measured; the measured number falls inside the stated range.
By their numbers in this assay, from the lowest: compounds 3 and 4 (each within the scatter of the next); then compound 2; then compound 1.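

In this assay the series now has its first comparison that differs in one place: going from 4-nitrophenyl to phenyl on the ester gives a number 14.2 percentage points lower from compound 2 to compound 4 (beyond the scatter). So the group on this aromatic carbon, para to a large group, does register in the read-out on the core of compound 2, with nitro the higher of the two, although the step is only modest. Nothing shown explains this difference.

On these data alone, with only hydrogen and nitro compared at this place, it remains open how an amine or a carboxylic acid there would read on the same core. Compounds 1 and 3 still connect to the others by no single change, so whether the nitro step carries over to their core cannot be read.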